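Phenoxy in place of methoxy on a naphthol series

The source may hold more compounds than are shown below. What is called first, only, known or untested is meant among the compounds shown, and "the series" means these compounds.

Three compounds share a naphthol core carrying a benzylic arm. Compound 1 `Oc1c(Cc2cccnc2)ccc2ccccc12` bears a pyridine, and in an assay on RBL-1 cells with Polyunsaturated fatty acid 5-lipoxygenase (Rattus norvegicus) as the target (on this read-out higher numbers stand for weaker inhibition and lower numbers for stronger inhibition), compound 1 gives 230 nM. Compound 2 `COc1ccc(Cc2ccc3ccccc3c2O)cc1` carries a methoxy-substituted phenyl, and in this assay compound 2 gives 75 nM. Compound 3 `COc1cccc(Cc2ccc3ccccc3c2O)c1` carries the methoxy group at a different position of the phenyl, and in this assay compound 3 gives 110 nM. Among these three numbers compound 3 holds the second highest. Its nearest neighbour is compound 2, whose number lies within the usual scatter of it, so no order between the two can be read. The furthest is compound 1, whose number stands beyond the scatter above that of compound 3.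

Compound 4 `Oc1c(Cc2cccc(Oc3ccccc3)c2)ccc2ccccc12` is the next member. Relative to compound 3 the change is phenyl in place of methyl on an oxygen on an aromatic ring. Among the measured compounds shown here, no measured pair shows this exchange, so the size of the step is open. Keeping the arm and the core of compound 3 unchanged, the step from compound 3 to compound 4 is expected to stay close to the scatter, a 1.2-fold higher number from compound 3 to compound 4 (0.07 log units; within the scatter). Compound 4 is therefore estimated at 130 nM, with a range from 40 nM to 450 nM.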

Compound 4, half-maximal inhibitory concentration: 83 nM
Beside the measured number, compound 4's estimate is 1.6-fold (0.19 log units) above it; the range from low to high includes it.
By their numbers in this assay, from the lowest: compounds 2, 4 and 3 (each within the scatter of the next); then compound 1.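

Exchanging methyl for phenyl on the oxygen on the aromatic ring brings in a whole six-membered aromatic ring of carbon only, and yet in this assay the result is a 1.3-fold lower number from compound 3 to compound 4 (0.12 log units; within the scatter). Among the compounds shown here, this is the first step between two compounds that differ in one place, and it shows that the read-out at this oxygen stays within the scatter when methoxy becomes phenoxy, so no gain or loss can be claimed for either group. No measurement offered here explains why the read-out holds across this exchange.

The compounds shown leave open whether this holds only for phenyl or also for other groups on the same oxygen, such as benzyl, a longer alkyl chain, or a chain ending in an amine or a carboxylic acid. On these data alone, they also rest on a single pair in one assay, so whether a phenyl ring bearing its own substituent, such as chloro or methoxy, would stay as close to compound 3 remains unknown.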